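The source may report more compounds than this note shows. Statements on the series, on what has been measured and on what is new or still open speak of the compounds shown alone.

Measured so far in a toxicity assay on CCRF-CEM cells (Homo sapiens) for cytotoxicity; a lower number here means that less compound is tolerated, a higher number that more compound is tolerated:
Compound 1 `Oc1cccc2c1nc(-c1c(F)cccc1F)n2Cc1c(F)cccc1F`: > 100 uM
Compound 2 `[N-]=[N+]=NCc1cccc2c1nc(-c1c(F)cccc1F)n2Cc1c(F)cccc1F`: > 100 uM

Compound 2 stands at > 100 uM, which is a limit of the assay and not a number. Compound 3 `NCc1cccc2c1nc(-c1c(F)cccc1F)n2Cc1c(F)cccc1F` carries amino in place of azido on a saturated chain carbon bound to an aromatic carbon. Within the data shown here, only one measured step bears on this change, a step that the two limits leave unreadable from compound 1 to compound 2, and it has no readable size. All the evidence is the limit of > 100 uM in this assay, at which 2 of the 2 values shown sit. No step beyond the scatter is therefore expected in this assay, in either direction, though this expectation rests on very little. The expected outcome is a number no higher from compound 2 to compound 3 (the limit leaves the size open). For compound 3 the estimate is 100 uM, with an expected range of 35 uM to 200 uM.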

Compound 3, half-maximal toxic concentration: 49.3 uM
Beside the measured number, compound 3's estimate is 2.0-fold (0.31 log units) above it; low and high end bracket the measured number.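

In this assay, among these compounds, aminomethyl is the first group at this position to give a number rather than a limit of the assay, which the earlier compounds could not do: the limit of > 100 uM in this assay, at which 2 of the 3 values shown sit. Amino in place of azido gives an at least 2.0-fold lower number from compound 2 to compound 3 (0.30 log units; that floor lies within the scatter), and aminomethyl in place of hydroxy gives an at least 2.0-fold lower number from compound 1 to compound 3 (0.30 log units; that floor lies within the scatter). Both are only floors, so neither step is shown to exceed the scatter.

From the compounds shown here alone, the true values of compound 1 and compound 2 remain unknown. Going by these compounds, it is also open whether a carboxylic acid or a dimethylaminomethyl group here would give a number or another limit.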